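Sulfonyl substituent change in a three-compound series

The source may report more compounds than this note shows. Statements on the series, on what has been measured and on what is new or still open speak of the compounds shown alone.

Measured so far:
compound 1, `Cn1c(=O)c(S(=O)(=O)Cc2ccc(F)cc2F)cc2cnc(Nc3ccc4[nH]ccc4c3)nc21`, 1000 nM
compound 2, `O=c1c(S(=O)(=O)c2ccc(F)cc2F)cc2cnc(Nc3ccc4[nH]ccc4c3)nc2n1CC1CC1`, 1000 nM
compound 3, `Cc1cc2cc(Nc3ncc4cc(S(=O)(=O)c5ccc(F)cc5F)c(=O)n(C)c4n3)ccc2[nH]1`, 750 nM

In a functional assay on K562 cells (Homo sapiens) for inhibition, read by trypan blue exclusion, with a stated time of 72 h (on this read-out lower numbers stand for stronger inhibition and higher numbers for weaker inhibition), compound 1 gives 1000 nM. That number is level with the one for compound 2 at the digits shown, and the two are together the highest of the three. Compound 3 gives 750 nM, a lower number than compound 1, but the gap lies within the scatter of this assay, so no order can be read from it. Among the compounds with values here, none of the three measured compounds differs from another in one place only, so no single-point step is available to lean on.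

Compound 4 is `Cn1c(=O)c(S(=O)(=O)c2ccc(Cl)cc2Cl)cc2cnc(Nc3ccc4[nH]ccc4c3)nc21`. Against compound 1 the change is 2,4-dichlorophenyl in place of 2,4-difluorobenzyl on a sulfonyl sulfur. Within the data shown here, the three measured numbers sit close together despite their differences on the sulfonyl sulfur and on the nitrogen of the shared core, and that is the only guide at hand. The step from compound 1 to compound 4 in this assay is therefore expected to be small, a 1.3-fold lower number from compound 1 to compound 4 (0.10 log units; within the scatter), with no direction beyond the scatter. For compound 4 the estimate in this assay is 800 nM, in a range from 300 nM to 2500 nM.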

Compound 4, half-maximal inhibitory concentration: 1000 nM
Compound 4: the middle estimate sits 1.3-fold (0.10 log units) below what was measured, within the range that was stated.
By their numbers in this assay, from the lowest: compounds 3, 1, 2 and 4 (each within the scatter of the next).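

In this assay, within the data shown here, 2,4-dichlorophenyl in place of 2,4-difluorobenzyl on a sulfonyl sulfur gives no change at the digits printed from compound 1 to compound 4 (within the scatter), and this is the only step so far that changes a single place. Earlier, the closeness of the numbers could only be seen across compounds differing in more than one place; here the same flat picture holds for one direct exchange, with 9 heavy atoms leaving and 8 heavy atoms entering, chlorine taking the place of fluorine and the carbon-only aromatic ring kept. No supporting measurement bears on this result, so the read-out gives the flat step without any explanation.

The exchange alters the halogen and the group's size together, so this single step cannot show whether either alone would leave the number unmoved, or whether the two merely offset each other. From the compounds shown here alone, it also remains open whether a group of a different kind on the sulfonyl sulfur, such as a morpholine, a piperazine or a chain ending in a carboxylic acid, would move the number beyond the scatter.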